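The compounds below may be only part of what the source reports. "The series", "measured", "known", "first", "only" and "open" are said of these compounds alone.

Working notes on the series. Compound 1 `Fc1ccccc1Nc1nc2nonc2nc1Nc1ccccc1OC(F)(F)F` gives 1700 nM in an assay on mitochondria from L6 cells (Rattus norvegicus) for activation, with a stated time of 90 min; a higher number here means that more compound is needed for the effect, a lower number that less compound is needed. Compound 2 `Fc1ccccc1Nc1nc2nonc2nc1Nc1cccc(OC(F)(F)F)c1` is built from the same atoms joined differently; the difference between the two cores is not broken down here. In this assay, for the measured compounds named here, compound 2 gives 600 nM, the lowest of the three numbers so far, with both other steps beyond the scatter. Compound 3 `Fc1ccccc1Nc1nc2nonc2nc1Nc1ccccc1C(F)(F)F` differs from compound 1 by trifluoromethyl in place of trifluoromethoxy on an aromatic carbon and in this assay compound 3 gives 1400 nM, so that a 1.2-fold lower number from compound 1 to compound 3 (0.08 log units; within the scatter).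

Compound 4 `Fc1ccccc1Nc1nc2nonc2nc1Nc1cccc(C(F)(F)F)c1` awaits measurement and differs from compound 2 by trifluoromethyl in place of trifluoromethoxy on an aromatic carbon. This is the same kind of change as that from compound 1 to compound 3, though the place differs: ortho to a large group in the measured pair, meta to a large group here. Because the measured pair showed a 1.2-fold lower number from compound 1 to compound 3 (0.08 log units; within the scatter), a comparably small step is expected, namely a 1.1-fold lower number from compound 2 to compound 4 (0.04 log units; within the scatter). Compound 4 is accordingly estimated at 550 nM, between 250 nM and 1200 nM.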

Compound 4, half-maximal effective concentration: < 1000 nM
Compound 4: only a limit was reported (the forecaster's own chance of this, stated with the estimate: 3%); the middle value does not contradict the limit.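

The result for compound 4 is only a limit, so no step from compound 2 to compound 4 can be read: the limit of < 1000 nM in this assay, at which 1 of the 4 values shown sits.

The compounds shown leave open whether trifluoromethyl in place of trifluoromethoxy, meta to a large group, changes the number in this assay.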